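The compounds below may be only part of what the source reports. "The series", "measured", "known", "first", "only" and "open" are said of these compounds alone.

Working notes on the series. Among the compounds with values here, compound 1 `Cc1nc(Nc2ccc(Cl)cc2)sc1C(=O)/C=C/c1ccccc1` is the only member with a measured number: in a functional assay on PC-3 cells (Homo sapiens) for cytotoxicity, read by MTT assay (on this read-out lower numbers stand for stronger inhibition and higher numbers for weaker inhibition), compound 1 gives 24600 nM. Compound 2 `COc1cccc(/C=C/C(=O)c2sc(Nc3ccccc3)nc2C)c1` is reported in this assay only as a limit, > 25000 nM. Compound 3 `Cc1nc(Nc2ccc(Cl)cc2)sc1C(=O)/C=C/c1ccc(Cl)cc1` likewise reaches only the limit, > 25000 nM. Within the data shown here, the one step between measured compounds that differ in a single place, an at least 1.0-fold higher number from compound 1 to compound 3 (0.00 log units; that floor lies within the scatter), runs from a number into a limit and so fixes no size beyond its floor; the whole picture is framed by the limit of > 25000 nM in this assay, at which 2 of the 3 values shown sit, which leaves compound 1 sitting just under that edge.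

Compound 4 `Cc1cccc(Nc2nc(C)c(C(=O)/C=C/c3ccccc3)s2)c1` differs from compound 1 by 3-methylphenyl in place of 4-chlorophenyl on a nitrogen on an aromatic ring. Among the measured compounds shown here, no measured pair exchanges one aryl group on that ring nitrogen for another; the sole measured step touches an aromatic carbon elsewhere in the molecule and bears on this change only as a reminder that the series sits at the weak end of the read-out. With nothing pointing either way, the step of a 1.0-fold higher number from compound 1 to compound 4 (0.01 log units; within the scatter) is expected to be none beyond the scatter, with a real chance that compound 4 is returned as a limit rather than a number. Compound 4 is therefore estimated at 25000 nM, with a range from 10000 nM to 60000 nM.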

Compound 4, half-maximal inhibitory concentration: 11700 nM
The estimate for compound 4 lay 2.1-fold (0.33 log units) above the measured number; low and high end bracket the measured number.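

Exchanging 4-chlorophenyl for 3-methylphenyl on the nitrogen gives, in this assay, a 2.1-fold lower number from compound 1 to compound 4 (0.32 log units; beyond the scatter). Within the data shown here, this is the first step with a number at both ends, and so the first that has a size rather than only a floor. It shows that the aryl group on this nitrogen can move the read-out beyond the scatter, though only modestly, and compound 4 adds a second number to a picture still framed by the assay's upper edge: the limit of > 25000 nM in this assay, at which 2 of the 4 values shown sit.

The exchange alters the substituent and its numbered place on the aryl ring together, so this single pair cannot show which of the two carries the step; 3-chlorophenyl or 4-methylphenyl on the same nitrogen would separate them. Also open, on these data alone, is whether the gain extends to other groups on that aryl ring, such as a carboxylic acid or an aminomethyl group, or whether the series stays at the weak end of the read-out.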